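Methyl in place of cyano on the benzoyl ring

A few compounds are considered here, and "the series" means these few. Any claim that something is new, unique, unknown or untested is made for them only; others in the source may bear on it.

Four compounds that share a common core are considered here. Compound 1 `CC(C)(C)N(NC(=O)c1cccc(C#N)c1)C(=O)c1ccccc1Cl` carries a 3-cyanophenyl on a carbonyl carbon, and in an assay on cells for agonist activity at ecdysone receptor (Bombyx mori), read by a luciferase reporter, with a stated time of 24 h (a lower number here means that less compound is needed, a higher number that more compound is needed for the effect), compound 1 gives 955 nM. Compound 2 `Cc1cccc(C(=O)NN(C(=O)c2ccccc2Cl)C(C)(C)C)c1` differs from compound 1 by methyl in place of cyano on an aromatic carbon, and in this assay compound 2 gives 603 nM. Compound 3 `CC(C)(C)N(NC(=O)c1ccc(C#N)cc1)C(=O)c1ccccc1Cl` is built from the same atoms as compound 1 but joined differently, the difference between the two cores being (4-cyanophenyl in place of 3-cyanophenyl on a carbonyl carbon); in this assay compound 3 gives 603 nM. The step of a 1.6-fold lower number from compound 1 to compound 2 (0.20 log units; within the scatter) and the step of a 1.6-fold lower number from compound 1 to compound 3 (0.20 log units; within the scatter) are both small, and the step of no change at the digits printed from compound 2 to compound 3 (within the scatter) shows the two values level as far as the digits go. Compound 4 `Cc1ccc(C(=O)NN(C(=O)c2ccccc2Cl)C(C)(C)C)cc1` has not yet been measured in this assay.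

Compound 4 differs from compound 3 by methyl in place of cyano on an aromatic carbon. This is the same kind of change as that from compound 1 to compound 2, though the place is not identical: in compound 1 the group sits meta to a large group, whereas in compound 3 it sits para to a large group. For the measured compounds named here, the one measured instance of this change, a 1.6-fold lower number from compound 1 to compound 2 (0.20 log units; within the scatter), stayed within the scatter. On that basis the step of a 1.3-fold lower number from compound 3 to compound 4 (0.13 log units; within the scatter) is expected to be small, because a 1.6-fold lower number from compound 1 to compound 2 (0.20 log units; within the scatter) was small. Compound 4 is therefore estimated to give 450 nM in this assay, with a plausible range from 200 nM to 1000 nM.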

Compound 4, half-maximal effective concentration: 18.6 nM
Estimate against measurement, compound 4: 24-fold (1.38 log units) above; measured number below the stated range.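

Methyl in place of cyano gives a 32-fold lower number from compound 3 to compound 4 (1.51 log units; beyond the scatter) in this assay, so the size of this change cannot be carried unaltered from one core to another in this series: the same change on two cores in this assay, a 1.6-fold lower number (0.20 log units; within the scatter) from compound 1 to compound 2 and a 32-fold lower number (1.51 log units; beyond the scatter) from compound 3 to compound 4, 20-fold (1.31 log units) apart, beyond the scatter of two such steps. The move of the methyl alone also matters, with a 32-fold lower number from compound 2 to compound 4 (1.51 log units; beyond the scatter), and the step between the two compounds that differ in both the group and its place is a 51-fold lower number from compound 1 to compound 4 (1.71 log units; beyond the scatter), which leaves compound 4 with the lowest number of the four. For the compounds shown here, with only two instances of the change, this shows that the step from compound 1 to compound 2 was no guide to the step from compound 3 to compound 4, but it gives no rule for any other core and does not explain why the two steps differ.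

The compounds shown leave open whether the low number of compound 4 is particular to the 4-methylphenyl group or would also appear with an ethyl, a methoxy or an amine in the same place. They also leave open whether the same step would appear on a core with a longer chain in place of the tert-butyl group.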